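Carbamoylmethyl in place of sec-butyl on a shared core

The source may report more compounds than this note shows. Statements on the series, on what has been measured and on what is new or still open speak of the compounds shown alone.

Compound 1, `O=C(O)[C@@H]1CCCN1C(=O)CN(c1nc(Cl)nc2[nH]cnc12)C1CC1`: 31.5%
Compound 2, `N=C(N)NCCC[C@H](NC(=O)CN(c1nc(Cl)nc2[nH]cnc12)C1CC1)C(=O)O`: 45.4%
Compound 3, `CC[C@H](C)[C@H](NC(=O)CN(c1nc(Cl)nc2[nH]cnc12)C1CC1)C(=O)O`: 30.3%

All three were tested in a functional assay on the whole organism (Tail, strain ICR) with Mus musculus as the target, in the tail flick test, with a stated time of 30 min, at a dose of 25 umol/kg by the oral route; on this read-out lower numbers stand for a weaker effect and higher numbers for a stronger effect at the one dose given. Compound 3 gives 30.3%, the lowest of the three numbers; compound 1, at 31.5%, lies within the scatter of it, while compound 2, at 45.4%, stands beyond the scatter above it. Compound 4, `NC(=O)C[C@H](NC(=O)CN(c1nc(Cl)nc2[nH]cnc12)C1CC1)C(=O)O`, differs from compound 3 by carbamoylmethyl in place of sec-butyl on a saturated chain carbon bound to an amide-type nitrogen and a carbonyl carbon. Among the measured compounds shown here, only one measured step touches this place: a number 15.1 percentage points lower from compound 2 to compound 3 (beyond the scatter). That step shows that exchanging the group on this chain carbon can move this assay by a modest amount, but neither the sec-butyl nor the carbamoylmethyl group has a second measured partner, so the direction for compound 4 rests on little. The change is therefore expected to give a small rise at most, and compound 4 is estimated at 37%, with a range from 24% to 52%, a step of a number 6.7 percentage points higher from compound 3 to compound 4 (within the scatter) that is expected to stay within the usual scatter.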

Compound 4, a percentage reported as activity, at one dose (the size of the read-out at that dose, not a potency): 29.7%
Compound 4: middle estimate off by 7.3 percentage points, on the high side, within the range that was stated.
By their numbers in this assay, from the lowest: compounds 4, 3 and 1 (each within the scatter of the next); then compound 2.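

In this assay, carbamoylmethyl and sec-butyl are interchangeable at this position, with a number 0.6 percentage points lower from compound 3 to compound 4 (within the scatter). The two groups have the same heavy-atom count, but carbamoylmethyl adds a hydrogen-bond donor and acceptor, and that difference has no measurable effect on this read-out. The other step, a number 15.7 percentage points lower from compound 2 to compound 4 (beyond the scatter), shows that the larger group of compound 2 stands apart from the smaller carbamoylmethyl-bearing chain just as it did from sec-butyl, so compound 2 is now the only one of these chain-carbon variants with a higher number.

No measurement here offers a reason for either step. From the compounds shown here alone, it remains open whether an amine or a carboxylic acid at the end of a chain as long as that in compound 2 would keep the higher number, which would help separate the effect of chain length from that of the end group.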